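The compounds below may be only part of what the source reports. "The series", "measured", "known", "first", "only" and "open" are said of these compounds alone.

Measured so far:
- compound 1, `Cc1cc(OCCCCCCC[N+]23CCN(CC2)CC3)ccc1-n1cc(C(=O)Nc2cc(F)cc(F)c2)c(=O)c2ccc(N(C)C)nc21`: "not active" (no number reported)
- compound 2, `CN(C)c1ccc2c(=O)c(C(=O)Nc3cc(F)cc(F)c3)cn(-c3ccc(OCCCCCCC[N+]45CCN(CC4)CC5)cc3Cl)c2n1`: 40.1%

Of the compounds shown here, two have been tested in an assay on LX2 cells for inhibition of COL1A1 promoter (Homo sapiens), read by a luciferase reporter, with a stated time of 24 h, tested at 20 uM; a higher number here means a stronger effect of the compound at the concentration tested, a lower number a weaker effect. Compound 1, `Cc1cc(OCCCCCCC[N+]23CCN(CC2)CC3)ccc1-n1cc(C(=O)Nc2cc(F)cc(F)c2)c(=O)c2ccc(N(C)C)nc21`, is recorded in this assay as "not active" (no number reported), with no number attached. Among the measured compounds shown here, compound 2, `CN(C)c1ccc2c(=O)c(C(=O)Nc3cc(F)cc(F)c3)cn(-c3ccc(OCCCCCCC[N+]45CCN(CC4)CC5)cc3Cl)c2n1`, gives 40.1% in this assay and therefore carries the only numerical value in the set; nothing else is available to place it against, and no step between two measured compounds can be drawn.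

Compound 3, `CC[N+]1(CCCCCCCOc2ccc(-n3cc(C(=O)Nc4cc(F)cc(F)c4)c(=O)c4ccc(N(C)C)nc43)c(Cl)c2)CCCC1`, has not yet been measured in this assay. It differs from compound 2 in one place: a group of 7 heavy atoms (6 carbon, 1 nitrogen; one five-membered non-aromatic ring with 1 hetero atom) in place of a group of 8 heavy atoms (6 carbon, 2 nitrogen; 2 six-membered non-aromatic rings with 2 hetero atoms each), on a saturated chain carbon, seven bonds along the chain from an oxygen on an aromatic ring. Both the group that leaves and the group that enters carry a net charge of plus one, and both sit seven bonds along the chain from the oxygen on the aromatic ring. For the measured compounds named here, with a single measured number and no measured step to rest on, the expectation for the change from compound 2 to compound 3 in this assay is a small one, a number 5.1 percentage points lower from compound 2 to compound 3 (within the scatter), of no clear direction and within the usual scatter. Compound 3 is accordingly estimated to give 35% in this assay, within a range from 15% to 55%.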

Compound 3, a percentage reported as inhibition, at one concentration (the size of the read-out at that concentration, not a potency): "not active" (no number reported)
For compound 3 the study gives words and no number, so the estimate cannot be set against anything.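

In this assay compound 3 is recorded in words alone, as is compound 1, so no step can be read from compound 2 to compound 3. Nothing measured here bears on a cause for this result. The compounds shown leave open how the charged ring group on the chain relates to the read-out, with compound 2 alone carrying a number.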